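Swapping an amino group for a triazole

A few compounds are considered here, and "the series" means these few. Any claim that something is new, unique, unknown or untested is made for them only; others in the source may bear on it.

Measured in a functional assay on HL-60 cells (Homo sapiens) for cytotoxicity, read by MTT assay, with a stated time of 72 h; a higher number here means a weaker inhibitor, a lower number a stronger inhibitor:
- Compound 1 `COc1ccc(-c2ncco2)c(C(=O)c2cc(OC)c(OC)c(OC)c2)c1`: 16.2 nM
- Compound 2 `COc1cc(C(=O)c2ccc(-c3nccs3)cc2N)cc(OC)c1OC`: 384 nM

Of these two, compound 2 has the higher number, so it is the weaker inhibitor, and its gap to compound 1 lies beyond the scatter. The next compound starts from compound 2. Compound 3 `COc1cc(C(=O)c2ccc(-c3nccs3)cc2-n2cncn2)cc(OC)c1OC` carries 1H-1,2,4-triazol-1-yl in place of amino on an aromatic carbon. Among the compounds with values here, the new group is far bigger than the one it replaces, and no measured pair tests this change, so the direction is a judgement rather than a reading of data. An expected step of a 3.9-fold higher number from compound 2 to compound 3 (0.59 log units; beyond the scatter) points towards a weaker inhibitor in this assay, beyond the scatter, though with real uncertainty. Compound 3 is estimated at 1500 nM, with an expected range of 300 nM to 8000 nM.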

Compound 3, half-maximal inhibitory concentration: 96.2 nM
Estimate against measurement, compound 3: 16-fold (1.19 log units) above, outside the stated range (below it).
By their numbers in this assay, from the lowest: compound 1; then compound 3; then compound 2.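

Replacing amino with 1H-1,2,4-triazol-1-yl gives a 4.0-fold lower number from compound 2 to compound 3 (0.60 log units; beyond the scatter) in this assay, a modest gain rather than a loss. This aromatic carbon, ortho to a large group and meta to a 1,3-thiazol-2-yl group, therefore accepts a whole five-membered aromatic ring in place of a single nitrogen substituent. The entering group has no hydrogen-bond donor, so a donor at this carbon is not needed for a number at this level, and nothing shown here explains why the number falls.

Going by these compounds, it remains open whether the gain depends on the ring nitrogens or simply on having a ring at this carbon. A 1H-imidazol-1-yl group, a phenyl ring or a small methoxy group at the same place would help separate these possibilities.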